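Replacing thiophen-2-yl with 2,4,6-trimethylphenyl in the series

The compounds below may be only part of what the source reports. "The series", "measured", "known", "first", "only" and "open" are said of these compounds alone.

Of the compounds shown here, two have been read so far in a functional assay on NCI-H460 cells (Homo sapiens) for inhibition, read by MTT assay, with a stated time of 48 h; a lower number here means a stronger inhibitor, a higher number a weaker inhibitor. Compound 1 (`O=C(CC(c1ccc(Cl)cc1)C(C(=O)Nc1ccccn1)C(=O)Nc1ccccn1)c1ccc(F)cc1`) gives 26800 nM. Compound 2 (`O=C(CC(c1cccs1)C(C(=O)Nc1ccccn1)C(=O)Nc1ccccn1)c1ccccc1`) is recorded as "not active" (no number reported), so it has no single number and no exact place on the scale. Among the measured compounds shown here, the two also differ in more than one place, so no measured step links them.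

The next entry, compound 3 (`Cc1cc(C)c(C(CC(=O)c2ccccc2)C(C(=O)Nc2ccccn2)C(=O)Nc2ccccn2)c(C)c1`), has not yet been measured. The change is 2,4,6-trimethylphenyl in place of thiophen-2-yl on a saturated chain carbon bound to two saturated chain carbons. A six-membered aromatic ring of carbon only thus replaces a five-membered aromatic ring with 1 hetero atom, on a saturated chain carbon bound to two saturated chain carbons.

For the measured compounds named here, no measured step shows what this change does in this assay. Going by the values given here, the only numerical anchor is compound 1 at 26800 nM, so only a modest move from compound 2 towards measurable but weak inhibition is expected, and another reading without a number remains quite possible. If a number is reported, compound 3 is estimated at 40000 nM, with an expected range of 15000 nM to 100000 nM.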

Compound 3, half-maximal inhibitory concentration: 23200 nM
For compound 3 the middle estimate is 1.7-fold (0.24 log units) above the measured one; the range from low to high includes it.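

Compound 2 has no number and compound 3 differs from compound 1 in more than one place, so no new step can be read from compound 3. Nothing measured here accounts for the result. From the compounds shown here alone, what replacing thiophen-2-yl with 2,4,6-trimethylphenyl does in this assay between two compounds that both carry numbers remains open.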